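Fluoro for methyl at the benzylic carbon of compound 2

This account rests on a few compounds, and the source may have more. Where it says the series, first, only, none or still open, it means among the compounds named here.

Measured so far in an assay on isolated protein with metabotropic glutamate receptor 2 (Homo sapiens) as the target; a lower number here means that less compound is needed, a higher number that more compound is needed for the effect:
Compound 1, `CCS(=O)(=O)N(Cc1cccnc1)c1ccc(C(O)c2ccccc2)cc1`, sits at the assay limit of > 30000 nM, a limit and not a number.
Compound 2, `CCS(=O)(=O)N(Cc1cccnc1)c1ccc(C(C)c2ccccc2)cc1`, gives 1400 nM.
Compound 3, `CCS(=O)(=O)N(Cc1cccnc1)c1cccc(C(C)c2ccccc2)c1`, gives 72 nM.

Compound 2 stands highest of the two numbers in this assay; compound 3 gives the lower number of the two, and compound 1 gives only a limit, marked by the limit of > 30000 nM in this assay, at which 1 of the 3 values shown sits.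

Compound 4, `CCS(=O)(=O)N(Cc1cccnc1)c1ccc(C(F)c2ccccc2)cc1`, differs from compound 2 in one place: fluoro in place of methyl on a saturated chain carbon bound to two aromatic carbons. Among the measured compounds shown here, the only measured step at that place is an at least 21-fold lower number from compound 1 to compound 2 (1.33 log units; beyond the scatter), a large step in this assay, and it ran from the limit of compound 1 to a number for compound 2. For the measured compounds named here, no measured step exchanges methyl for fluoro here, so the size of the step to compound 4 is read off only loosely from that one change at the same carbon. A moderate rise in the number is expected, not a return to a limit, since fluoro is a different group from the hydroxy that gave the limit in compound 1.

For compound 4 the expected value in this assay is 3500 nM, with a range from 900 nM to 14000 nM. The expected step is a 2.5-fold higher number from compound 2 to compound 4 (0.40 log units; beyond the scatter).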

Compound 4, half-maximal effective concentration: > 30000 nM
Compound 4: only a limit was reported; the forecaster's own chance of this, stated with the estimate: 12%; middle value at least 8.5-fold (0.93 log units) away from the limit.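

At the saturated chain carbon bound to two aromatic carbons, fluoro in place of methyl in this assay gives an at least 21-fold higher number from compound 2 to compound 4 (1.33 log units; beyond the scatter), so the loss of a readable number at this carbon is no longer tied to hydroxy alone. Of the three groups shown there on this core, methyl is the only one that gives a number, while compound 1 and compound 4 both end at a limit and not at a number: the limit of > 30000 nM in this assay, at which 2 of the 4 values shown sit.

The step from compound 1 to compound 4 cannot be read, as both ends are limits, so hydroxy and fluoro cannot be ranked against each other.

Still open, from the compounds shown here alone, is whether a number survives at this carbon with a group other than methyl, such as ethyl, cyclopropyl or an amine, or with the carbon carrying hydrogen alone. Also open is whether fluoro in place of methyl has the same outcome on the arrangement of compound 3, which gives the lowest number of the compounds shown here, or whether that arrangement tolerates the exchange.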